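The source may hold more compounds than are shown below. What is called first, only, known or untested is meant among the compounds shown, and "the series" means these compounds.

In a functional assay on V79 cells (Cricetulus griseus) for cytotoxicity, read by colony formation (a lower number here means a stronger inhibitor, a higher number a weaker inhibitor), compound 2 (`CC1CN(c2c(F)cc3c(=O)c(C(=O)O)cn(C4CC4)c3c2Cl)CC(C)N1`) gives 140 ug/mL, a higher number than compound 1 (`CCNCC1CCN(c2c(F)cc3c(=O)c(C(=O)O)cn(C4CC4)c3c2OC)C1`) at 22 ug/mL; 22 ug/mL (2 entries). Compound 3 (`COc1c(N2CC(C)NC(C)C2)c(F)cc2c(=O)c(C(=O)O)cn(C3CC3)c12`) keeps the 3,5-dimethylpiperazin-1-yl group of compound 2 and has methoxy in place of chloro on an aromatic carbon. Within the data shown here, no measured pair isolates this change. Compound 1, at 22 ug/mL; 22 ug/mL (2 entries), also carries methoxy, but it differs from compound 3 elsewhere as well, so it offers only a weak hint towards a lower number. A modest move in that direction is expected, a 1.6-fold lower number from compound 2 to compound 3 (0.19 log units; within the scatter), and it may not clear the scatter. The estimated value for compound 3 is 90 ug/mL, within a range of 35 ug/mL to 220 ug/mL.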

Compound 3, half-maximal inhibitory concentration: > 500 ug/mL
Compound 3 gave a limit, no number (the forecaster's own chance of this, stated with the estimate: 10%); middle value at least 5.5-fold (0.74 log units) away from the limit.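

Among these compounds, this is the first pair to isolate this position: with the 3,5-dimethylpiperazin-1-yl group held fixed, methoxy in place of chloro on an aromatic carbon gives an at least 3.5-fold higher number from compound 2 to compound 3 (0.55 log units; beyond the scatter) in this assay. On these data alone, the true size of that step stays unknown, since one end of it is a limit and not a number: the limit of > 500 ug/mL in this assay, at which 1 of the 3 values shown sits. The choice between chloro and methoxy at this position therefore matters here, with methoxy on the weaker side.

As far as these compounds go, whether the step holds with the side chain of compound 1 remains open. From the compounds shown here alone, how a methyl, a hydroxyl or an amine on this aromatic carbon would read also remains open.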